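Returning to a Directly Attached Aromatic Ring

The compounds below may be only part of what the source reports. "The series", "measured", "known", "first", "only" and "open" are said of these compounds alone.

Going by the values given here, compound 2 `C=C(Br)C(=O)Nc1cccc(-c2cn3nc(Cc4ccc(Cl)cc4)sc3n2)c1` is the weaker of the two compounds measured so far: in a functional assay on L1210 cells (Mus musculus) for inhibition, read by cell counting, with a stated time of 2 days (a higher number here means a weaker inhibitor, a lower number a stronger inhibitor), compound 2 gives 2300 nM, the highest number of the pair. Among the compounds with values here, its nearest neighbour, compound 1 `C=C(Br)C(=O)Nc1cccc(-c2cn3nc(-c4ccc(F)cc4)sc3n2)c1`, gives 250 nM in this assay, and the single step between them, a 9.2-fold higher number from compound 1 to compound 2 (0.96 log units; beyond the scatter), arose from one change alone, 4-chlorobenzyl in place of 4-fluorophenyl on an aromatic carbon of the shared core.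

Compound 3 `C=C(Br)C(=O)Nc1cccc(-c2cn3nc(-c4cccc(OC)c4)sc3n2)c1` differs from compound 2 in one place: 3-methoxyphenyl in place of 4-chlorobenzyl on an aromatic carbon. The entering group is, like the 4-fluorophenyl of compound 1, a six-membered aromatic ring of carbon only, so the change undoes the kind of move that weakened compound 1 into compound 2. Within the data shown here, only that one step bears on the question, and it was modest but beyond the scatter. The expected outcome is therefore a lower number, roughly reversing that step, as a 7.7-fold lower number from compound 2 to compound 3 (0.88 log units; beyond the scatter).

For compound 3 the estimate in this assay is 300 nM, with a likely range from 100 nM to 1000 nM.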

Compound 3, half-maximal inhibitory concentration: 580 nM
Estimate against measurement, compound 3: 1.9-fold (0.29 log units) below, within the range that was stated.
By their numbers in this assay, from the lowest: compound 1; then compound 3; then compound 2.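

Here the step of a 4.0-fold lower number from compound 2 to compound 3 (0.60 log units; beyond the scatter) in this assay shows that the 4-chlorobenzyl is not the only group this place on the shared core can carry at that level of activity: a different aromatic ring, 3-methoxyphenyl, also gives a lower number, so both compounds with a directly attached ring stand below compound 2. The two directly attached rings are not interchangeable, however, as the step of a 2.3-fold higher number from compound 1 to compound 3 (0.37 log units; beyond the scatter) shows, so what the ring carries, or where it carries it, also counts here and not only how the ring is attached. Nothing available explains either step.

Compounds 1 and 3 differ in both the kind of group on the ring and its place there, and compounds 1 and 2 differ in both the halogen and the attachment, so neither effect can be read alone. A 4-methoxyphenyl or 3-fluorophenyl would separate the group from its place on the ring, a 4-fluorobenzyl would separate the attachment from the halogen, and a plain phenyl would show what the bare ring gives.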